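Turning the hydroxyl stereocentre in a thiophene carboxamide

This account rests on a few compounds, and the source may have more. Where it says the series, first, only, none or still open, it means among the compounds named here.

Measured compounds:
compound 1 `CC1(C)Cc2c(sc(NC(=O)c3ccccc3O)c2C(N)=O)C(C)(C)O1` — 4 nM
compound 2 `CC1(C)Cc2c(sc(NC(=O)C3CCNC3=O)c2C(N)=O)C(C)(C)O1` — 101 nM
compound 3 `CC1(C)Cc2c(sc(NC(=O)[C@@H](O)C(C)(C)C)c2C(N)=O)C(C)(C)O1` — 2.7 nM

All three share one core and differ only in the group attached to the amide carbonyl carbon. In an assay on cells for positive allosteric modulation of Cystic fibrosis transmembrane conductance regulator variant F508del (Homo sapiens), with stated times of 10 min and 7 s, in the presence of a further agent that is not named here (on this read-out lower numbers stand for an effect already at smaller amounts and higher numbers for an effect only at larger amounts of compound), compound 1 gives 4 nM. Exchanging the 2-hydroxyphenyl for 2-oxopyrrolidin-3-yl gives a 25-fold higher number from compound 1 to compound 2 (1.40 log units; beyond the scatter), so compound 2 reaches 101 nM. Exchanging it instead for 1-hydroxy-2,2-dimethylpropyl gives a 1.5-fold lower number from compound 1 to compound 3 (0.17 log units; within the scatter), and compound 3 gives 2.7 nM, the lowest of the three numbers, though its gap to compound 1 lies within the scatter; only compound 2 stands clearly apart, by a 37-fold lower number from compound 2 to compound 3 (1.57 log units; beyond the scatter).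

Compound 4 `CC1(C)Cc2c(sc(NC(=O)[C@H](O)C(C)(C)C)c2C(N)=O)C(C)(C)O1` keeps every atom and bond of compound 3: the two compounds have the same atoms and bonds and differ only in configuration as drawn: 1 of 1 stereo elements differ; a stereocentre at a saturated chain carbon is drawn S in compound 3 and R in compound 4. For the measured compounds named here, none of the measured steps concerns a change of configuration alone; each of them swaps one group for another, so none bears directly on this step. Mirror-image pairs can give similar numbers or very different ones, and the data give no guide to which. As a cautious expectation, compound 4 is estimated at 15 nM, with a range from 2 nM to 150 nM. The step expected in this assay is a 5.6-fold higher number from compound 3 to compound 4 (0.74 log units; beyond the scatter), a higher number but one carrying wide uncertainty.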

Compound 4, half-maximal effective concentration: 127 nM
For compound 4 the middle estimate is 8.5-fold (0.93 log units) below the measured one, and the stated range covers the measured number.
By their numbers in this assay, from the lowest: compounds 3 and 1 (each within the scatter of the next); then compounds 2 and 4 (each within the scatter of the next).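

In this assay, the stereocentre in the 1-hydroxy-2,2-dimethylpropyl group proves to be a sensitive point: with no atom or bond changed, inverting it gives a 47-fold higher number from compound 3 to compound 4 (1.67 log units; beyond the scatter). The name of a group is therefore not enough to predict its effect here, since the R form gives a 32-fold higher number from compound 1 to compound 4 (1.50 log units; beyond the scatter), whereas the S form in compound 3 lies within the scatter of compound 1, and a 1.3-fold higher number from compound 2 to compound 4 (0.10 log units; within the scatter) leaves compound 4 within the scatter of the 2-oxopyrrolidin-3-yl compound. The large gap can be assigned to the spatial arrangement at this one carbon alone, because nothing else separates the pair: the fact that compounds 3 and 4 differ only in the configuration as drawn.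

The compounds shown leave open whether the hydroxyl itself is needed, a question that an amine or a methoxy group on the same carbon would address. They also leave open whether a shorter chain, such as 1-hydroxyethyl, would respond to inversion as sharply as the 1-hydroxy-2,2-dimethylpropyl group does.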